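Urea series: dihalophenyl in place of ethoxyphenyl

The compounds below may be only part of what the source reports. "The series", "measured", "known", "first", "only" and "open" are said of these compounds alone.

Measured so far in a functional assay on MGC-803 cells (Homo sapiens) for antiproliferative activity, read by MTT assay, with a stated time of 48 h; on this read-out lower numbers stand for stronger inhibition and higher numbers for weaker inhibition:
compound 1 `O=C(Nc1cccc(CNc2nccnc2Cl)c1)Nc1cccc2ccccc12`, for which compound 1 gives 32700 nM
compound 2 `CCOc1ccc(NC(=O)Nc2cccc(CNc3nccnc3Cl)c2)cc1`, for which compound 2 gives 7240 nM
compound 3 `Cc1ccc(NC(=O)Nc2cccc(CNc3nccnc3Cl)c2)cc1Cl`, for which compound 3 gives 17500 nM

Compound 2 stands at the lowest of the three numbers in this assay. Compound 3 is its nearest neighbour and compound 1 its furthest; both gaps lie beyond the scatter. Among the measured compounds shown here, only one measured step leaves compound 2 in a single place: a 2.4-fold higher number from compound 2 to compound 3 (0.38 log units; beyond the scatter). For the measured compounds named here, no step between compound 1 and either of the others is defined, so their values speak only for themselves.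

Compound 4 `O=C(Nc1cccc(CNc2nccnc2Cl)c1)Nc1ccc(Cl)cc1Br` differs from compound 2 in the same position: 2-bromo-4-chlorophenyl in place of 4-ethoxyphenyl on an amide-type nitrogen. The step to compound 3 is the only one that bears on this change, since it also exchanges 4-ethoxyphenyl for a halogen-bearing phenyl on the amide-type nitrogen. A step of similar size and direction is therefore expected, that is a modest rise in this assay, a 2.1-fold higher number from compound 2 to compound 4 (0.32 log units; beyond the scatter). Compound 4 is expected to give 15000 nM, within 6000 nM to 40000 nM.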

Compound 4, half-maximal inhibitory concentration: 7480 nM
Compound 4: the middle estimate sits 2.0-fold (0.30 log units) above what was measured, and the stated range covers the measured number.
By their numbers in this assay, from the lowest: compounds 2 and 4 (each within the scatter of the next); then compounds 3 and 1 (each within the scatter of the next).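

In this assay, among the compounds shown here, 2-bromo-4-chlorophenyl in place of 4-ethoxyphenyl on the amide-type nitrogen gives a 1.0-fold higher number from compound 2 to compound 4 (0.01 log units; within the scatter), so losing 4-ethoxyphenyl at this place does not by itself carry a cost, as the single earlier step might have suggested. The step of a 2.3-fold lower number from compound 3 to compound 4 (0.37 log units; beyond the scatter) shows that the two replacement groups are not interchangeable here: the result depends on which substituted phenyl enters, not only on which group leaves. Nothing at hand explains the difference between these two groups.

Still open, going by these compounds, is what the bromine and the chlorine each contribute, and whether 4-chlorophenyl would match 2-bromo-4-chlorophenyl at this place. Also open, on these data alone, is how a phenyl carrying a carboxylic acid or a dimethylamino group would behave on this nitrogen.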